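The source may report more compounds than this note shows. Statements on the series, on what has been measured and on what is new or still open speak of the compounds shown alone.

Measured in a functional assay on MCF7 cells (Homo sapiens) for antiproliferative activity, with a stated time of 5 days; a lower number here means a stronger inhibitor, a higher number a weaker inhibitor:
compound 1 `COc1ccc(-c2[nH]c3ccc(OC)cc3c2C=O)cc1` gives 180 nM
compound 2 `COc1ccc(-c2[nH]c3ccc(F)cc3c2C=O)cc1` gives 240 nM
compound 3 `CCCCCc1ccc2[nH]c(-c3ccc(OC)cc3)c(C=O)c2c1` gives 20 nM

Compound 3 has the lowest number of the three, with steps of a 9.0-fold lower number from compound 1 to compound 3 (0.95 log units; beyond the scatter) and a 12-fold lower number from compound 2 to compound 3 (1.08 log units; beyond the scatter). Compound 4 `CCCCCc1ccc2[nH]c(-c3ccc(C(F)(F)F)cc3)c(C=O)c2c1` keeps the pentyl chain and carries trifluoromethyl in place of methoxy on an aromatic carbon, para to a large group (trifluoromethyl in place of methoxy on an aromatic carbon).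

Among the compounds with values here, no measured compound lacks this methoxy, so no step speaks directly to the change. The pentyl steps concern another place on the core. The nearest guide is the exchange of a different methoxy for fluoro, a 1.3-fold higher number from compound 1 to compound 2 (0.12 log units; within the scatter), which lies within the scatter and is only weak support. A modest step to a higher number in this assay is expected, with a wide margin, as the group in question has never been varied. The expected change is a 3.0-fold higher number from compound 3 to compound 4 (0.48 log units; beyond the scatter). For compound 4 the estimated value is 60 nM, with an expected range of 15 nM to 300 nM.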

Compound 4, half-maximal inhibitory concentration: 67 nM
Estimate against measurement, compound 4: 1.1-fold (0.05 log units) below, and the stated range covers the measured number.
By their numbers in this assay, from the lowest: compound 3; then compound 4; then compounds 1 and 2 (each within the scatter of the next).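

In this assay, within the data shown here, trifluoromethyl in place of methoxy on this aromatic carbon, para to a large group, gives the first step at this place (a 3.4-fold higher number from compound 3 to compound 4 (0.53 log units; beyond the scatter)), and that step lies beyond the scatter. The place therefore responds to a change of group, but the step is modest, and compound 4 keeps a number of 67 nM although the entering trifluoromethyl counts no hydrogen-bond acceptor where the methoxy counted one. Nothing measured on these compounds gives a reason for the step.

With only two groups shown here, it remains open whether the higher number follows from losing the methoxy or from gaining trifluoromethyl, and a hydroxyl, an amine or plain hydrogen at this place would help separate the two. On these data alone, it also remains open whether the same exchange gives a similar step on a core carrying fluoro or methoxy instead of the pentyl chain.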